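Compound 2 to Compound 3: Relocating a Hydroxy Group

This account rests on a few compounds, and the source may have more. Where it says the series, first, only, none or still open, it means among the compounds named here.

Measured so far in a functional assay on OVCAR-5 cells (Homo sapiens) for inhibition, read by sulforhodamine B assay, with a stated time of 48 h; a higher number here means a weaker inhibitor of growth, a lower number a stronger inhibitor of growth:
- compound 1 `O=C(Cc1csc2nc(-c3ccc(Br)cc3)cn12)N/N=C/c1ccccc1` gives 30900 nM as its value
- compound 2 `O=C(Cc1csc2nc(-c3ccc(Br)cc3)cn12)N/N=C/c1ccccc1O` gives 5500 nM as its value

Going by the values given here, compound 2 holds the lower of these two numbers, and its gap to compound 1, the only neighbour, lies beyond the scatter. Compound 3 `O=C(Cc1csc2nc(-c3ccc(Br)cc3)cn12)N/N=C/c1ccc(O)cc1` has not yet been measured. Its structure departs from that of compound 2 as follows: 4-hydroxyphenyl in place of 2-hydroxyphenyl on a carbon with a double bond to nitrogen and the rest of the molecule stays the same. Among the compounds with values here, one measured step bears on this change, namely a 5.6-fold lower number from compound 1 to compound 2 (0.75 log units; beyond the scatter) when hydroxy takes the place of hydrogen on an aromatic carbon. That step is modest but beyond the scatter. Within the data shown here, compound 3 also carries a hydroxy, but no measured compound has 4-hydroxyphenyl, so how much of that gain remains is unknown. Part of it is expected to persist. In this assay the expected change is a 2.2-fold higher number from compound 2 to compound 3 (0.34 log units; beyond the scatter) by estimate, a smaller move than the measured step and toward a higher number. Compound 3 is estimated at 12000 nM with an expected range from 4000 nM to 30000 nM as its likely span.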

Compound 3, concentration for 50% growth inhibition: 27500 nM
The estimate for compound 3 lay 2.3-fold (0.36 log units) below the measured number; measured number inside the range.
By their numbers in this assay, from the lowest: compound 2; then compounds 3 and 1 (each within the scatter of the next).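

In this assay, moving the hydroxy from 2-hydroxyphenyl to 4-hydroxyphenyl on the carbon with a double bond to nitrogen gives a 5.0-fold higher number from compound 2 to compound 3 (0.70 log units; beyond the scatter), so the two groups, though built from the same atoms and equal in their counted hydrogen-bond donors and acceptors, do not behave alike here. Adding a hydroxy to the plain phenyl ring at the 4-hydroxyphenyl placement gives a 1.1-fold lower number from compound 1 to compound 3 (0.05 log units; within the scatter), which lies within the scatter, so among these three compounds the gain from a hydroxy appears only with 2-hydroxyphenyl and the presence of a hydroxy alone does not secure it. No experimental evidence at hand accounts for this difference between the two placements.

On these data alone, it remains open whether the hydroxy of 2-hydroxyphenyl is itself required, or whether a methoxy group, an amine or a fluorine in its place would give a similar number. The compounds shown also leave open whether the gap between 2-hydroxyphenyl and 4-hydroxyphenyl would persist if the bromine of the shared core gave way to a chlorine or a methoxy group.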